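Amide chain lengthening in the shared core series

The source may hold more compounds than are shown below. What is called first, only, known or untested is meant among the compounds shown, and "the series" means these compounds.

Measured so far:
Compound 1 `C=CC1=C(C(=O)NCCC)C(c2ccc(F)cc2)OC1` gives > 100000 nM in a functional assay on SW480 cells (Homo sapiens) for cytotoxicity, read by MTT assay, with a stated time of 24 h; a higher number here means a weaker inhibitor, a lower number a stronger inhibitor. This value is a limit of the assay, not a number.
Compound 2 `C=CC1=C(C(=O)NCC(C)C)C(c2ccc(F)cc2)OC1` gives > 100000 nM in this assay. This value is also a limit of the assay, not a number.

Compound 2 therefore stands only at a limit in this assay; no number for it is known. Going by the values given here, the single measured step at the amide chain, a step that the two limits leave unreadable from compound 1 to compound 2, cannot be read, as the limit of > 100000 nM in this assay, at which 2 of the 2 values shown sit, shows. The pair thus gives no size for any change at this position.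

Compound 3 `C=CC1=C(C(=O)NCCCCC)C(c2ccc(F)cc2)OC1` differs from compound 2 by butyl in place of isopropyl on a saturated chain carbon bound to an amide-type nitrogen. Among the compounds with values here, the one measured step that bears on this position is a step that the two limits leave unreadable from compound 1 to compound 2, and it is unreadable. Within the data shown here, no measured step shows a change at the amide chain that leaves the limit.

On this basis compound 3 is expected to remain at the limit as well. The expected step of a number no higher from compound 2 to compound 3 (the limit leaves the size open) is none beyond the scatter. For compound 3 the estimate in this assay is 100000 nM, with a range from 30000 nM to 300000 nM, and a limit rather than a number is the most likely outcome.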

Compound 3, half-maximal inhibitory concentration: > 100000 nM
Compound 3 ended at the assay's limit; the forecaster's own chance of this, stated with the estimate: 85%; the middle value lies on the limit itself.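

No step among compound 1, compound 2 and compound 3 can be read, because each value is a limit of the assay and not a number: the limit of > 100000 nM in this assay, at which 3 of the 3 values shown sit.

The compounds shown leave open whether any amide chain on the shared core gives a number in this assay and, if so, how large a change at this position would be.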